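The source may report more compounds than this note shows. Statements on the series, on what has been measured and on what is new or still open speak of the compounds shown alone.

Measured so far in a functional assay on A549 cells (Homo sapiens) for cytotoxicity (a higher number here means a weaker inhibitor, a lower number a stronger inhibitor), as follows:
compound 1 `C=C/C=C\[C@H](C)[C@H](OC(N)=O)[C@@H](C)[C@H](O)[C@@H](C)C/C(C)=C\[C@H](C)[C@@H](O)[C@@H](C)/C=C\CCc1ccc(C)c(F)c1` gives 4000 nM
compound 2 `C=C/C=C\[C@H](C)[C@H](OC(N)=O)[C@@H](C)[C@H](O)[C@@H](C)C/C(C)=C\[C@H](C)[C@@H](O)[C@@H](C)/C=C\CCc1cccc(F)c1` gives 650 nM
compound 3 `C=C/C=C\[C@H](C)[C@H](OC(N)=O)[C@@H](C)[C@H](O)[C@@H](C)C/C(C)=C\[C@H](C)[C@@H](O)[C@@H](C)/C=C\CCc1cccc(Cl)c1` gives 580 nM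

Compound 3 sits at the low end of these numbers, level within the scatter with its nearest neighbour (a 1.1-fold lower number from compound 2 to compound 3 (0.05 log units; within the scatter)) and clearly apart from the third (a 6.9-fold lower number from compound 1 to compound 3 (0.84 log units; beyond the scatter)).

Next is compound 4 `C=C/C=C\[C@H](C)[C@H](OC(N)=O)[C@@H](C)[C@H](O)[C@@H](C)C/C(C)=C\[C@H](C)[C@@H](O)[C@@H](C)/C=C\CCc1sccc1C`, which carries 3-methylthiophen-2-yl in place of 3-chlorophenyl on a saturated chain carbon, two bonds along the chain from a double-bonded chain carbon.

Among the measured compounds shown here, no measured step covers this exchange of rings, so the evidence is indirect. Chloro in place of fluoro on an aromatic carbon (a 1.1-fold lower number from compound 2 to compound 3 (0.05 log units; within the scatter)) stays within the scatter. Hydrogen in place of methyl on an aromatic carbon (a 6.2-fold lower number from compound 1 to compound 2 (0.79 log units; beyond the scatter)) is a modest step beyond it. Compound 4 also bears a methyl on its ring, which makes compound 1 (4000 nM) the upper guide and compound 3 (580 nM) the lower one.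

The expected result is a small rise in the number (a 1.7-fold higher number from compound 3 to compound 4 (0.24 log units; within the scatter)) in this assay, with real uncertainty in both directions. Compound 4 is estimated at 1000 nM in this assay, with an expected range from 350 nM to 3000 nM for now.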

Compound 4, half-maximal inhibitory concentration: 790 nM
Beside the measured number, compound 4's estimate is 1.3-fold (0.10 log units) above it; low and high end bracket the measured number.
By their numbers in this assay, from the lowest: compounds 3, 2 and 4 (each within the scatter of the next); then compound 1.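

At this place, on a saturated chain carbon, two bonds along the chain from a double-bonded chain carbon, replacing a six-membered aromatic ring of carbon only with a five-membered aromatic ring with 1 hetero atom leaves the number in this assay level with both chlorophenyl and fluorophenyl partners (a 1.4-fold higher number from compound 3 to compound 4 (0.13 log units; within the scatter); a 1.2-fold higher number from compound 2 to compound 4 (0.08 log units; within the scatter)). Among the compounds shown here, a methyl on the ring therefore does not go with a high number in every case: 3-methylthiophen-2-yl also carries one, yet it stands clearly apart from the 3-fluoro-4-methylphenyl group (a 5.1-fold lower number from compound 1 to compound 4 (0.70 log units; beyond the scatter)), so compound 1 remains the only high number among the four. No measurement of any property of these groups is available to account for the level numbers or for the gap to compound 1.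

The compounds shown leave open how much the methyl of 3-methylthiophen-2-yl contributes, as the plain thiophen-2-yl group does not appear among them, so ring and methyl cannot be read apart. They also leave open whether this place accepts anything other than an aromatic ring with no net charge, such as a carboxylic acid, an amine or a longer chain ending in the same ring.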